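Shifting the hydroxyl arm around the piperidine ring

A few compounds are considered here, and "the series" means these few. Any claim that something is new, unique, unknown or untested is made for them only; others in the source may bear on it.

Compound 1 `CC(C)(C)c1ccc(C(=O)N2CCC3(CC2)C(=O)N(CC(=O)N2CCNCC2)CN3c2ccccc2)cc1`: 22000 nM
Compound 2 `CC(C)(C)c1ccc(C(=O)N2CCC3(CC2)C(=O)N(CC(=O)NCN)CN3c2ccccc2)cc1`: 26500 nM
Compound 3 `CC(C)(C)c1ccc(C(=O)N2CCC3(CC2)C(=O)N(CC(=O)N2CCCCC2CCO)CN3c2ccccc2)cc1`: 6100 nM

In an assay on HEK293 cells for displacement of a labelled ligand from NPC1-like intracellular cholesterol transporter 1 (Homo sapiens) (on this read-out higher numbers stand for weaker inhibition and lower numbers for stronger inhibition), compound 3 gives 6100 nM, the lowest of the three numbers; its steps to the others are a 3.6-fold lower number from compound 1 to compound 3 (0.56 log units; beyond the scatter) and a 4.3-fold lower number from compound 2 to compound 3 (0.64 log units; beyond the scatter), both beyond the scatter. Compound 4 `CC(C)(C)c1ccc(C(=O)N2CCC3(CC2)C(=O)N(CC(=O)N2CCCC(CO)C2)CN3c2ccccc2)cc1` is not yet measured. Its change from compound 3 is 3-(hydroxymethyl)piperidin-1-yl in place of 2-(2-hydroxyethyl)piperidin-1-yl on a carbonyl carbon. Among the compounds with values here, no measured step changes one piperidine for another; the two steps above replace unrelated amines with the 2-(2-hydroxyethyl)piperidin-1-yl group and so say little about this swap. He therefore expects little movement in this assay, at most a small step within the scatter, a 1.3-fold higher number from compound 3 to compound 4 (0.12 log units; within the scatter). Compound 4 is estimated at 8000 nM, with a range from 3500 nM to 18000 nM.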

Compound 4, half-maximal inhibitory concentration: 8200 nM
The estimate for compound 4 lay 1.0-fold (0.01 log units) below the measured number, and the stated range covers the measured number.
By their numbers in this assay, from the lowest: compounds 3 and 4 (each within the scatter of the next); then compounds 1 and 2 (each within the scatter of the next).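

In this assay the exchange of one piperidine for another on the carbonyl carbon can now be read, and it stays within the scatter (a 1.3-fold higher number from compound 3 to compound 4 (0.13 log units; within the scatter)). The 3-(hydroxymethyl)piperidin-1-yl group also gives lower numbers than the two non-piperidine amines, both beyond the scatter (a 3.2-fold lower number from compound 2 to compound 4 (0.51 log units; beyond the scatter); a 2.7-fold lower number from compound 1 to compound 4 (0.43 log units; beyond the scatter)), so among these compounds this is shared by both hydroxyl-bearing piperidines. No available evidence explains these steps.

The compounds shown leave open whether the hydroxyl or the piperidine ring carries the difference. An unsubstituted piperidine or a methoxy group in place of the hydroxyl would separate the two.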